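The source may hold more compounds than are shown below. What is called first, only, known or untested is meant among the compounds shown, and "the series" means these compounds.

Measured compounds:
compound 1, `Cc1nc(-c2ccc(C(F)(F)F)cc2)sc1CNc1ccc(C(=O)O)cc1`, in a functional assay on CHO cells for agonist activity at Free fatty acid receptor 1 (Homo sapiens), read by a luciferase reporter (a higher number here means a larger maximal response, a lower number a smaller maximal response), compound 1 gives 10%
compound 2, `Cc1nc(-c2ccc(C(F)(F)F)cc2)sc1CNc1ccc(CC(=O)O)cc1`, compound 2 gives 18%
compound 3, `Cc1nc(-c2ccc(C(F)(F)F)cc2)sc1CNc1ccc(CC(C)C(=O)O)cc1`, compound 3 gives 100%

Compound 3 stands highest of the three numbers: its nearest neighbour is compound 2, with a step of a number 82 percentage points higher from compound 2 to compound 3 (beyond the scatter), and its furthest neighbour is compound 1, with a step of a number 90 percentage points higher from compound 1 to compound 3 (beyond the scatter), both beyond the scatter. The step from compound 1 to compound 2, a number 8 percentage points higher from compound 1 to compound 2 (within the scatter), lies within the scatter.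

Compound 4, `Cc1nc(-c2ccc(C(F)(F)F)cc2)sc1CNc1ccc(CCC(=O)NC(C)C)cc1`, follows from compound 3 by one change, ((isopropylcarbamoyl)methyl in place of 1-carboxyethyl on a saturated chain carbon bound to an aromatic carbon). Among the measured compounds shown here, no measured pair shows what happens when the acid is exchanged for an amide; the measured steps only show that lengthening the chain that carries the acid raised the maximal response, above all in the step from compound 2 to compound 3. The change to compound 4 removes that acid altogether while keeping a chain of comparable length, so the measured steps give no direct guide and the expectation is uncertain. An estimated drop in this assay seems the more likely outcome, with the step from compound 3 to compound 4 estimated at a number 55 percentage points lower from compound 3 to compound 4 (beyond the scatter). For compound 4 the expected value is 45%, estimated between 10% and 90%.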

Compound 4, largest response reached (reported as percent of maximum), in percent of the reference or control that the assay uses: 84%
Compound 4: the middle estimate sits 39 percentage points below what was measured; the range from low to high includes it.
By their numbers in this assay, from the lowest: compounds 1 and 2 (each within the scatter of the next); then compound 4; then compound 3.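

In this assay, the acid proves not to be needed for a high response at this position: the 2-(isopropylcarbamoyl)ethyl chain of compound 4 carries an amide instead, and the result is only a modest loss, with a number 16 percentage points lower from compound 3 to compound 4 (beyond the scatter). The same chain also stands far above the shorter acid chains, with a number 66 percentage points higher from compound 2 to compound 4 (beyond the scatter) and with a number 74 percentage points higher from compound 1 to compound 4 (beyond the scatter), so among these four compounds the high responses go with the two longer chains, whichever group ends them. Nothing available explains why the amide holds up so well.

A 2-carboxyethyl chain would help show how much the methyl branch of compound 3 contributes. A primary amide or a tert-butyl amide on the same chain would test how much depends on the isopropyl group.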